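Acetyl for chloro on the pendant phenyl ring

The source may report more compounds than this note shows. Statements on the series, on what has been measured and on what is new or still open speak of the compounds shown alone.

compound 1 `COc1cc(-c2ccnc3cc(-c4ccc(Cl)cc4)nn23)cc(OC)c1OC`: 3340 nM
compound 2 `COc1cc(-c2ccnc3c(-c4ccc(C)cc4)cnn23)cc(OC)c1OC`: > 10000 nM (a limit of the assay)
compound 3 `COc1ccc(-c2cc3nccc(-c4cc(OC)c(OC)c(OC)c4)n3n2)cc1[N+](=O)[O-]`: > 10000 nM (a limit of the assay)

Among the compounds with values here, in a functional assay on HCT-116 cells (Homo sapiens) for inhibition, read by CCK-8 assay, with a stated time of 48 h (on this read-out higher numbers stand for weaker inhibition and lower numbers for stronger inhibition), compound 1 gives 3340 nM, the only number in the set. Compound 2 reaches only the limit > 10000 nM. Compound 3 likewise stops at the limit > 10000 nM. Both sit at the limit of > 10000 nM in this assay, at which 2 of the 3 values shown sit. Compound 1 is thus the one point from which to go. Compound 4 `COc1cc(-c2ccnc3cc(-c4ccc(C(C)=O)cc4)nn23)cc(OC)c1OC` differs from it by acetyl in place of chloro on an aromatic carbon. Within the data shown here, no pair of measured compounds differs in a single place, so no measured step sizes this change. For compound 4 a step of a 1.2-fold higher number from compound 1 to compound 4 (0.08 log units; within the scatter) is expected, not clearly beyond the scatter in either direction. Compound 4 is estimated at 4000 nM, between 1500 nM and 10000 nM, with a fair chance that only the limit is reported.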

Compound 4, half-maximal inhibitory concentration: 4390 nM
Compound 4: middle estimate off by 1.1-fold (0.04 log units), on the low side, and the stated range covers the measured number.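

Replacing chloro with acetyl on the pendant phenyl ring gives a 1.3-fold higher number from compound 1 to compound 4 (0.12 log units; within the scatter), so this position accepts the larger group, with its hydrogen-bond acceptor, without a step beyond the scatter. Chloro is therefore not required here for a measurable number. Compound 4 also reads as a number and not as a limit, unlike the two compounds that remain there: the limit of > 10000 nM in this assay, at which 2 of the 4 values shown sit.

As far as these compounds go, whether an amine or a carboxylic acid at this place would move the number beyond the scatter stays open. A single step also cannot show which feature of either group matters, if any does.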